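Methoxy to hydroxy on the pendant phenyl ring

This account rests on a few compounds, and the source may have more. Where it says the series, first, only, none or still open, it means among the compounds named here.

The series is read in a functional assay on cells (Mus musculus) for antiproliferative activity, read by sulforhodamine B assay, with a stated time of 5 days; a lower number here means a stronger inhibitor, a higher number a weaker inhibitor. Compound 1 `CC(C)(C)c1ccc(O)c(C2(c3cccnc3)C(=O)Nc3ccccc32)c1` gives only a limit there, > 20000 nM, which is the assay limit of > 20000 nM in this assay, at which 1 of the 3 values shown sits, rather than a number. Compound 2 `CC(C)(C)c1ccc(O)c(C2(c3ccccc3)C(=O)Nc3ccc(I)cc32)c1` gives 14900 nM in this assay. Compound 3 `COc1ccc(C2(c3cc(C(C)(C)C)ccc3O)C(=O)Nc3c2ccc(F)c3F)cc1` gives 12300 nM in this assay, the lower of the two numbers recorded, though its gap to compound 2 lies within the scatter, so no ranking between the two is claimed.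

Compound 4 `CC(C)(C)c1ccc(O)c(C2(c3ccc(O)cc3)C(=O)Nc3c2ccc(F)c3F)c1` is compound 3 with a single change: hydrogen in place of methyl on an oxygen on an aromatic ring, methoxy to hydroxy, 4-methoxyphenyl to 4-hydroxyphenyl. Among the measured compounds shown here, no measured pair isolates this change, so there is nothing to calibrate its size against. The expectation is a step of a 1.1-fold lower number from compound 3 to compound 4 (0.05 log units; within the scatter) of no size beyond the scatter, in either direction. Compound 4 is therefore estimated at 11000 nM in this assay, with a range of 4000 nM to 25000 nM.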

Compound 4, half-maximal inhibitory concentration: 15300 nM
Compound 4: middle estimate off by 1.4-fold (0.14 log units), on the low side, within the range that was stated.
By their numbers in this assay, from the lowest: compounds 3, 2 and 4 (each within the scatter of the next). At a limit, above all of these: compound 1.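

The step at this place in this assay is a 1.2-fold higher number from compound 3 to compound 4 (0.09 log units; within the scatter), so 4-methoxyphenyl and 4-hydroxyphenyl are not told apart by this read-out. Among the compounds shown here, this is the first pair that differs in one place, and it gives a first size for this change, though it rests on that single pair and says nothing about why the number holds. The other reading in the series is not a number, and it belongs to compound 1: the limit of > 20000 nM in this assay, at which 1 of the 4 values shown sits.

From the compounds shown here alone, whether an amine or a carboxylic acid in place of the methoxy group would move the number beyond the scatter stays open. Also open, going by these compounds, is whether hydrogen in place of methyl on this oxygen gives a similar step on a core carrying other substituents, such as that of compound 2.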